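A few compounds are considered here, and "the series" means these few. Any claim that something is new, unique, unknown or untested is made for them only; others in the source may bear on it.

Working notes on the series, which so far has two measured compounds. Compound 1 `CNC(=O)c1ccc(Sc2ccc(NC(=S)Nc3cccc(C)c3)cc2)nc1` gives > 100000 nM in a functional assay on B16-BL6 cells (Mus musculus) for cytotoxicity, read by MTT assay, with a stated time of 48 h (on this read-out higher numbers stand for weaker inhibition and lower numbers for stronger inhibition), and this value is a limit of the assay, not a number. Compound 2 `CNC(=O)c1ccc(Sc2ccc(NC(=S)Nc3ccc(F)c(C(F)(F)F)c3)cc2)nc1` gives 29300 nM in this assay. Among the measured compounds shown here, this is the only numeric value available, so compound 2 has no second number to be ranked against.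

Compound 3 `CNC(=O)c1ccc(Sc2ccc(NC(=S)Nc3ccc(F)c(F)c3)cc2)nc1` has fluoro in place of trifluoromethyl on an aromatic carbon, ortho to a fluoro group and meta to a large group (fluoro in place of trifluoromethyl on an aromatic carbon). For the measured compounds named here, no measured step in this assay covers this change, so the expectation rests on the two values alone. Compound 2 at 29300 nM is the starting point. It leaves limited room before the limit reached by compound 1. A modest weakening is expected, and a report of only a limit would not be surprising. The expected step is a 2.2-fold higher number from compound 2 to compound 3 (0.35 log units; beyond the scatter). For compound 3 the estimated value is 65000 nM, with an expected range of 28000 nM to 100000 nM.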

Compound 3, half-maximal inhibitory concentration: 52600 nM
Estimate against measurement, compound 3: 1.2-fold (0.09 log units) above; low and high end bracket the measured number.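

In this assay, fluoro in place of trifluoromethyl on an aromatic carbon, ortho to a fluoro group and meta to a large group, gives a 1.8-fold higher number from compound 2 to compound 3 (0.25 log units; within the scatter), so this change does not separate compound 2 from compound 3, even though the entering group has 1 heavy atom and the leaving group has 4. The second comparison, 3,4-difluorophenyl in place of 3-methylphenyl on an amide-type nitrogen, gives an at least 1.9-fold lower number from compound 1 to compound 3 (0.27 log units; that floor lies within the scatter), which does not establish a real separation between these two compounds. That step can be read only as a floor because the value of compound 1 is a limit of the assay, not a number: the limit of > 100000 nM in this assay, at which 1 of the 3 values shown sits.

On these data alone, whether an amine or a carboxylic acid on this aromatic carbon would read differently from trifluoromethyl and fluoro in this assay remains open. Also open, as far as these compounds go, is whether the step from trifluoromethyl to fluoro would stay within the scatter on a compound without the neighbouring fluoro group, such as one carrying a methoxy group there instead.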